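Crown-ether esters against WiDr cell growth

The source may report more compounds than this note shows. Statements on the series, on what has been measured and on what is new or still open speak of the compounds shown alone.

Compound 1, `O=C(CCCCCc1ccccc1)OCC1COCCOCCOCCOCCOCCO1`, gives only a limit in a functional assay on WiDr cells (Homo sapiens) for inhibition, read by sulforhodamine B assay, with a stated time of 48 h; on this read-out higher numbers stand for weaker inhibition of growth and lower numbers for stronger inhibition of growth: > 100000 nM. Compound 2, `O=C(CCCCC1CCCCC1)OCC1COCCOCCOCCOCCOCCO1`, gives 33000 nM in this assay.

Within the data shown here, compound 2 thus holds the only number among the two; the other value is a limit (the limit of > 100000 nM in this assay, at which 1 of the 2 values shown sits). Among the measured compounds shown here, the one measured step, an at least 3.0-fold lower number from compound 1 to compound 2 (0.48 log units; beyond the scatter), swaps one ring for another far out on the chain. Compound 3, `CC/C=C/CC(=O)OCC1COCCOCCOCCOCCOCCO1`, differs otherwise: but-1-en-1-yl in place of 3-cyclohexylpropyl on a saturated chain carbon bound to a carbonyl carbon. That step bears only loosely, since a ring leaves and nothing replaces it. A weaker result is expected, a 2.4-fold higher number from compound 2 to compound 3 (0.38 log units; beyond the scatter), so compound 3 is estimated at 80000 nM, between 25000 nM and 300000 nM.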

Compound 3, concentration for 50% growth inhibition: > 100000 nM
Compound 3: no number, only a limit (the forecaster's own chance of this, stated with the estimate: 45%); at least 1.2-fold (0.09 log units) between middle value and limit.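

At the saturated chain carbon bound to a carbonyl carbon, but-1-en-1-yl in place of 3-cyclohexylpropyl gives an at least 3.0-fold higher number from compound 2 to compound 3 (0.48 log units; beyond the scatter) in this assay. Among the three compounds, only compound 2, with its cyclohexyl ring, gives a number rather than a limit. The step between compound 1 and compound 3 cannot be read, because both values are limits: the limit of > 100000 nM in this assay, at which 2 of the 3 values shown sit.

On these data alone, compound 3 loses the ring and shortens the group in a single change, so the separate effect of each remains open. As far as these compounds go, how a nonyl chain, with no ring, would read in this assay also remains open.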